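The source may report more compounds than this note shows. Statements on the series, on what has been measured and on what is new or still open speak of the compounds shown alone.

Compound 1 `Cc1ccc2oc(SCC(=O)Nc3ccc(-c4nc(-c5ccccc5)c(-c5ccccc5)n4C)cc3)nc2c1` gives 59.5% in a functional assay on HT-29 cells (Homo sapiens) for cytotoxicity, read by MTT assay, with a stated time of 24 h, tested at 32 ug/mL; on this read-out lower numbers stand for a weaker effect and higher numbers for a stronger effect at the one concentration tested. Compound 2 `Cc1nnc(SCC(=O)Nc2ccc(-c3nc(-c4ccccc4)c(-c4ccccc4)n3C)cc2)s1` gives 87.1%. Compound 3 `CCN1CCN(CC(=O)Nc2ccc(-c3nc(-c4ccccc4)c(-c4ccccc4)n3C)cc2)CC1` gives 38.8%.

Compound 3 stands lowest of the three measured numbers; its nearest neighbour is compound 1, as the step of a number 20.7 percentage points lower from compound 1 to compound 3 (beyond the scatter) shows, and the step of a number 48.3 percentage points lower from compound 2 to compound 3 (beyond the scatter) places it furthest from compound 2. Compound 4 `CN(C)/C=C/N1CCN(CC(=O)Nc2ccc(-c3nc(-c4ccccc4)c(-c4ccccc4)n3C)cc2)CC1` differs from compound 3 by 2-(dimethylamino)ethenyl in place of ethyl on an amine nitrogen in a ring. Going by the values given here, no measured step exchanges one group for another on that ring nitrogen. The two steps that reach compound 3 replace the whole group on the chain carbon bound to the carbonyl carbon, so they only show that this end of the molecule moves the number in this assay, not which way a smaller change at the ring nitrogen goes. A step of roughly the size of the scatter is therefore expected, with no firm direction: a number 3.2 percentage points higher from compound 3 to compound 4 (within the scatter). Compound 4 is estimated at 42%, between 22% and 65%.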

Compound 4, a percentage reported as activity, at one concentration (the size of the read-out at that concentration, not a potency): 29.8%
The estimate for compound 4 lay 12.2 percentage points above the measured number; the measured number falls inside the stated range.
By their numbers in this assay, from the lowest: compounds 4 and 3 (each within the scatter of the next); then compound 1; then compound 2.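

In this assay the exchange on the ring nitrogen gives a number 9 percentage points lower from compound 3 to compound 4 (within the scatter) so ethyl and 2-(dimethylamino)ethenyl cannot be told apart at this position. With a number 57.3 percentage points lower from compound 2 to compound 4 (beyond the scatter) and a number 29.7 percentage points lower from compound 1 to compound 4 (beyond the scatter) the replacement of the whole group on the saturated chain carbon still outweighs this change at the ring nitrogen. Nothing measured gives a reason for these numbers.

From the compounds shown here alone, whether a plain hydrogen, an acetyl group or a longer chain such as butyl on that ring nitrogen would move the number beyond the scatter remains open.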